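The compounds below may be only part of what the source reports. "The series", "measured", "known", "first", "only" and "open" are said of these compounds alone.

Values in a functional assay on K562 cells (Homo sapiens) for inhibition, read by trypan blue exclusion, with a stated time of 24 h, tested at 10 uM (on this read-out lower numbers stand for less inhibition of growth and higher numbers for more inhibition of growth at the one concentration tested), so far:
- compound 1 `NC(=O)c1cc(Cl)ccc1NC(=O)COc1ccccc1` gives 87% as measured
- compound 2 `Cc1ccc(OCC(=O)Nc2ccc(Cl)cc2C(N)=O)cc1` gives 24.1% as measured

Compound 2 holds the lower of the two numbers in this assay and the gap to compound 1 is large, with a number 62.9 percentage points lower from compound 1 to compound 2 (beyond the scatter) on methyl in place of hydrogen on an aromatic carbon. Compound 3 `Cc1ccc(OCC(=O)Nc2ccc(I)cc2C(N)=O)cc1` is still unmeasured. Its difference from compound 2 is iodo in place of chloro on an aromatic carbon and, in short, iodo in place of chloro on an aromatic carbon.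

For the measured compounds named here, no measured step covers an exchange of one halogen for another. Going by the values given here, the only step available, a number 62.9 percentage points lower from compound 1 to compound 2 (beyond the scatter) as the single reference, concerns a methyl at a different place. It bears on this change only indirectly: it shows that one small change can move the number far in this pair, so the range is kept wide. No step beyond the scatter is expected, and the data give no firm direction. The estimated step is a number 5.9 percentage points higher from compound 2 to compound 3 (within the scatter) and no more than that is expected. For compound 3 the expected value is 30% with an estimated range from 8% to 65% in this series.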

Compound 3, percent growth inhibition at one concentration: 49.8%
Beside the measured number, compound 3's estimate is 19.8 percentage points below it; measured number inside the range.
By their numbers in this assay, from the lowest: compound 2; then compound 3; then compound 1.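

In this assay the halogen place responds to the exchange of chloro for iodo (a number 25.7 percentage points higher from compound 2 to compound 3 (beyond the scatter)), and the shift is towards more inhibition of growth. The earlier pair showed a step only at the methyl place, so the read-out of this series is now seen to move at a second place, on the aromatic carbon meta to a carbamoyl group and para to a large group. The new step is the smaller of the two (a number 62.9 percentage points lower from compound 1 to compound 2 (beyond the scatter)), and it was seen with the methyl present in both compounds, so it describes this exchange on the core of compound 2 only, and no measured property in the data accounts for it.

From the compounds shown here alone, whether iodo gives a similar step without the methyl stays open, since compound 1 and compound 3 differ in two places and the methyl and halogen effects cannot be separated between them. Also open, going by these compounds, is how the number would follow along the halogens with bromo or fluoro at this place, and whether a non-halogen group such as an amine, a nitrile or a carboxylic acid would be tolerated there.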